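The source may report more compounds than this note shows. Statements on the series, on what has been measured and on what is new or still open speak of the compounds shown alone.

Compound 1, `COc1cc(-n2cnc3ccc(-c4ccc([N+](=O)[O-])cc4)cc32)cc(OC)c1OC`, gives 79 nM in a functional assay on SGC-7901 cells (Homo sapiens) for antiproliferative activity, read by MTT assay, with a stated time of 72 h; on this read-out higher numbers stand for weaker inhibition and lower numbers for stronger inhibition. Compound 2, `COc1cccc(-c2ccc3ncn(-c4cc(OC)c(OC)c(OC)c4)c3c2)c1`, gives 3310 nM in this assay. Compound 3, `COc1cc(-n2cnc3ccc(-c4ccccc4Cl)cc32)cc(OC)c1OC`, reaches only the limit of > 10000 nM in this assay.

Among the two numbers that are numbers, compound 2 holds the higher one; its nearest neighbour is compound 1, with a 42-fold higher number from compound 1 to compound 2 (1.62 log units; beyond the scatter). Compound 3 sits at the limit of > 10000 nM in this assay, at which 1 of the 3 values shown sits, so the step of an at least 3.0-fold higher number from compound 2 to compound 3 (0.48 log units; beyond the scatter) is known only as a floor.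

The step to the unmeasured compound 4, `COc1cc(-n2cnc3ccc(-c4ccc(F)cc4)cc32)cc(OC)c1OC`, is 4-fluorophenyl in place of 3-methoxyphenyl on an aromatic carbon. Among the compounds with values here, two measured steps bear on it. The swap of 4-nitrophenyl for 3-methoxyphenyl brought a 42-fold higher number from compound 1 to compound 2 (1.62 log units; beyond the scatter), and the swap of 3-methoxyphenyl for 2-chlorophenyl brought an at least 3.0-fold higher number from compound 2 to compound 3 (0.48 log units; beyond the scatter). Both show that the identity of this aryl group moves this assay by large amounts, and of the three aryl groups measured, 4-nitrophenyl gave the lowest number, in compound 1. Compound 4 carries 4-fluorophenyl, a group not yet measured here, so the direction rests on this resemblance of names alone; a drop in the number relative to compound 2 is expected, but a smaller one than the full distance back to compound 1. The step from compound 2 is therefore estimated as a 5.5-fold lower number from compound 2 to compound 4 (0.74 log units; beyond the scatter). Compound 4 is expected to give about 600 nM in this assay, most likely between 100 nM and 4000 nM.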

Compound 4, half-maximal inhibitory concentration: 3500 nM
For compound 4 the middle estimate is 5.8-fold (0.77 log units) below the measured one; low and high end bracket the measured number.
By their numbers in this assay, from the lowest: compound 1; then compounds 2 and 4 (each within the scatter of the next). At a limit, above all of these: compound 3.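

In this assay, the new result shows that 4-fluorophenyl and 3-methoxyphenyl cannot be told apart at this aromatic carbon, with a 1.1-fold higher number from compound 2 to compound 4 (0.02 log units; within the scatter). Only the substituent changes between the two 4-substituted phenyl groups. The fluoro in place of nitro swap shows that having a group at that same ring position does not by itself preserve the low number of compound 1, with a 44-fold higher number from compound 1 to compound 4 (1.65 log units; beyond the scatter) as the step. The step of an at least 2.8-fold lower number from compound 3 to compound 4 (0.45 log units; beyond the scatter) is known only as a floor, since compound 3 stands at a limit and not at a number: the limit of > 10000 nM in this assay, at which 1 of the 4 values shown sits.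

As far as these compounds go, what a nitrile, an amine or a carboxylic acid in place of the nitro of compound 1 would give remains open, so these compounds cannot say whether the low number belongs to nitro alone. Also open, from the compounds shown here alone, is whether the limit of compound 3 goes with chloro itself or with where it sits on the phenyl ring, a question that 4-chlorophenyl and 2-fluorophenyl would bear on.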